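This account rests on a few compounds, and the source may have more. Where it says the series, first, only, none or still open, it means among the compounds named here.

In an ADME assay for permeability, using PAMPA, at pH 7.4 (on this read-out higher numbers stand for higher permeability and lower numbers for lower permeability), compound 1 `CCc1ccc(NC(=O)Nc2cc(C)nc3ccccc23)cc1` gives 535 10^-6 cm/s, compound 2 `Cc1ccc(NC(=O)Nc2cc(C)nc3ccccc23)cc1` gives 669 10^-6 cm/s and compound 3 `Cc1cc(NC(=O)Nc2ncccc2C)c2ccccc2n1` gives 369 10^-6 cm/s, so compound 3 stands within the usual scatter of both others. Compound 4 `Cc1cc(NC(=O)Nc2ccc(Cl)cc2)c2ccccc2n1` carries 4-chlorophenyl in place of 3-methylpyridin-2-yl on an amide-type nitrogen. The nearest evidence is a 1.8-fold lower number from compound 2 to compound 3 (0.26 log units; within the scatter), which brings in the same 3-methylpyridin-2-yl on that nitrogen in place of 4-methylphenyl. A smaller change, hydrogen in place of methyl on a chain, gives a 1.3-fold higher number from compound 1 to compound 2 (0.10 log units; within the scatter). Among the compounds with values here, no measured compound carries chlorine, so the forecast is loose, and no step beyond the scatter is foreseen. The expected step is a 1.5-fold higher number from compound 3 to compound 4 (0.18 log units; within the scatter). For compound 4 the estimate is 560 10^-6 cm/s, with an expected range from 280 10^-6 cm/s to 1000 10^-6 cm/s.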

Compound 4, apparent permeability: 537 10^-6 cm/s
The estimate for compound 4 lay 1.0-fold (0.02 log units) above the measured number, within the range that was stated.
By their numbers in this assay, from the lowest: compounds 3, 1, 4 and 2 (each within the scatter of the next).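

In this assay, 4-chlorophenyl in place of 3-methylpyridin-2-yl on the amide-type nitrogen gives a 1.5-fold higher number from compound 3 to compound 4 (0.16 log units; within the scatter), so losing that group's ring nitrogen and hydrogen-bond acceptor leaves the read-out within the scatter. Chlorine also stands level with the carbon groups on the aromatic carbon: chloro in place of methyl gives a 1.2-fold lower number from compound 2 to compound 4 (0.10 log units; within the scatter), and chloro in place of ethyl gives a 1.0-fold higher number from compound 1 to compound 4 (0.00 log units; within the scatter). No supporting measurement accounts for these small steps. From the compounds shown here alone, every group on this nitrogen so far is a six-membered aromatic ring with no net charge, so whether an amine or a carboxylic acid on that ring would produce a step beyond the scatter remains open.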